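Ester exchange on the chain of compound 1

The source may hold more compounds than are shown below. What is called first, only, known or untested is meant among the compounds shown, and "the series" means these compounds.

In a functional assay on T47D cells (Homo sapiens) for cytotoxicity, read by colorimetric assay and MTT assay (a higher number here means a weaker inhibitor, a lower number a stronger inhibitor), compound 1 (`CCOC(=O)Cn1c(=O)c(-c2ccc(OC)cc2)cc2c(OC)cc(OC)cc21`) stands at 10000 nM as its measured value, level with compound 2 (`COc1ccc(-c2cc3c(OC)cc(OC)cc3n(CCC#N)c2=O)cc1`) at 10000 nM on the same read-out. Within the data shown here, the only measured step at this place (no change at the digits printed from compound 1 to compound 2 (within the scatter)) lies within the scatter. Compound 3 (`COc1ccc(-c2cc3c(OC)cc(OC)cc3n(CCC(=O)OCc3ccccc3)c2=O)cc1`) differs from compound 1 as follows ((benzyloxycarbonyl)methyl in place of ethoxycarbonyl on a saturated chain carbon bound to an aromatic nitrogen). The measured step brought in no ring, so it is thin evidence for this change. No step beyond the scatter is expected, and no change at the digits printed from compound 1 to compound 3 (within the scatter) is the estimated step in this assay for now. Compound 3 is estimated at 10000 nM within a range of 4000 nM to 25000 nM pending measurement.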

Compound 3, half-maximal inhibitory concentration: 10000 nM
For compound 3 middle estimate and measured number coincide at the digits printed, within the range that was stated.
By their numbers in this assay, from the lowest: compounds 1, 2 and 3 (each within the scatter of the next).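

In this assay the six-membered aromatic ring of carbon only, brought in by (benzyloxycarbonyl)methyl on a saturated chain carbon bound to an aromatic nitrogen, gives no step beyond the scatter (no change at the digits printed from compound 1 to compound 3 (within the scatter)). The same holds for benzyloxycarbonyl in place of cyano (no change at the digits printed from compound 2 to compound 3 (within the scatter)), so three different chain groups now read alike on the shared core. No measured evidence bears on this result.

From the compounds shown here alone, whether any group on this chain can separate from these three stays open. An amine or a carboxylic acid on the chain would test that.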